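Aryl amide series: amine replaced by butylsulfanyl at the aromatic carbon

The source may hold more compounds than are shown below. What is called first, only, known or untested is meant among the compounds shown, and "the series" means these compounds.

Measured so far:
compound 1 `CCC1CCN(c2cc(C(F)(F)F)ccc2CNC(=O)C(C)c2ccc(NS(C)(=O)=O)c(F)c2)CC1` — 0.7 nM
compound 2 `COc1ccc(N2CCN(c3cc(C(F)(F)F)ccc3CNC(=O)C(C)c3ccc(NS(C)(=O)=O)c(F)c3)CC2)cc1` — 1.6 nM

In an assay on CHO cells for antagonist activity at transient receptor potential cation channel subfamily V member 1 (Homo sapiens), read by FLIPR (a higher number here means a weaker inhibitor, a lower number a stronger inhibitor), compound 1 gives 0.7 nM, the lowest of the two numbers recorded; compound 2 gives 1.6 nM, a gap beyond the scatter. Compound 3 `CCCCSc1cc(C(F)(F)F)ccc1CNC(=O)C(C)c1ccc(NS(C)(=O)=O)c(F)c1` has not been measured. It differs from compound 1 in one place: butylsulfanyl in place of 4-ethylpiperidin-1-yl on an aromatic carbon. Going by the values given here, no measured pair shows this change. A modest loss is expected for compound 3, with a step of a 4.3-fold higher number from compound 1 to compound 3 (0.63 log units; beyond the scatter) somewhat beyond the scatter. Compound 3 is estimated at 3 nM, within a range of 0.8 nM to 12 nM.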

Compound 3, inhibition constant: 1.9 nM
Compound 3: the middle estimate sits 1.6-fold (0.20 log units) above what was measured; the measured number falls inside the stated range.
By their numbers in this assay, from the lowest: compound 1; then compounds 2 and 3 (each within the scatter of the next).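

In this assay, butylsulfanyl in place of 4-ethylpiperidin-1-yl on this aromatic carbon gives a 2.7-fold higher number from compound 1 to compound 3 (0.43 log units; beyond the scatter), a modest loss. The position therefore keeps much of the activity of compound 1 with an open chain carrying sulfur, without a ring or nitrogen at this carbon. No supporting data explain the size of this step.

Going by these compounds, whether the sulfur or the chain matters more remains open; butoxy or pentyl at this carbon would separate the two. Propylsulfanyl or hexylsulfanyl would test how far activity follows chain length.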